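Cyclopropyl Amide to Phenyl Carbamate on a Shared Core

A few compounds are considered here, and "the series" means these few. Any claim that something is new, unique, unknown or untested is made for them only; others in the source may bear on it.

Two compounds have been measured:
compound 1, `O=C(Nc1ccc2nc(NC(=O)C3CCCCC3)sc2c1)c1c(F)cccc1C(F)(F)F`, gives 0.032 ug/mL in a functional assay on WI-38 VA13 cells (Homo sapiens) for cytotoxicity; on this read-out lower numbers stand for an effect already at smaller amounts and higher numbers for an effect only at larger amounts of compound
compound 2, `O=C(Nc1ccc2nc(NC(=O)C3CC3)sc2c1)c1c(Cl)cccc1Cl`, gives 0.013 ug/mL in this assay

Compound 2 stands lowest of these two numbers; compound 1 is its nearest neighbour, with a higher number beyond the usual scatter. Compound 3, `O=C(Nc1nc2ccc(NC(=O)c3c(Cl)cccc3Cl)cc2s1)Oc1ccccc1`, differs from compound 2 by a single change: phenoxy in place of cyclopropyl on a carbonyl carbon. For the measured compounds named here, no measured pair shows this change, so its effect is unknown. This step, expected as a 1.5-fold higher number from compound 2 to compound 3 (0.19 log units; within the scatter), is guessed to be small or none beyond the scatter. Compound 3 is therefore expected near 0.02 ug/mL in this assay, somewhere between 0.005 ug/mL and 0.08 ug/mL.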

Compound 3, half-maximal effective concentration: 1.1 ug/mL
Beside the measured number, compound 3's estimate is 55-fold (1.74 log units) below it; measured number above the stated range.
By their numbers in this assay, from the lowest: compound 2; then compound 1; then compound 3.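

In this assay, replacing cyclopropyl with phenoxy on this carbonyl carbon gives an 85-fold higher number from compound 2 to compound 3 (1.93 log units; beyond the scatter) and so shows that the group here can change the number greatly. The earlier compounds shown here offered no single-change pair that could show this. Nothing measured here gives a reason for the step.

As far as these compounds go, whether the step follows from the oxygen or from the aromatic ring stays open. On the same carbonyl carbon, a benzyl group would keep the ring without the oxygen, and a methoxy group would keep the oxygen without the ring.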